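The compounds below may be only part of what the source reports. "The series", "measured", "known", "first", "only" and "open" are said of these compounds alone.

Compound 2, `Cc1noc(NS(=O)(=O)c2cccc3c(N4CCCCC4=O)cccc23)c1C`, and compound 1, `Cc1noc(NS(=O)(=O)c2cccc3c(N(C)C)cccc23)c1Cc1ccccc1`, share one core and differ only in the group that sits on it. In an assay on VSM-A10 cells for antagonist activity at Endothelin-1 receptor (Rattus norvegicus) (on this read-out lower numbers stand for stronger inhibition and higher numbers for weaker inhibition), compound 2 gives 270 nM, while compound 1 gives 50000 nM, so compound 2 stands at the lowest of the two numbers, and the gap to compound 1 lies well beyond the usual scatter. Compound 3, `Cc1noc(NC(=O)c2ccc(N)cc2)c1C`, is built on a different core. Compound 3 sits at the limit of > 32000 nM in this assay, at which 1 of the 3 values shown sits, which is a limit of the assay and not a number: > 32000 nM.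

Compound 4, `Cc1noc(NS(=O)(=O)c2cccc3c(N/C(S)=N/c4ccccc4)cccc23)c1C`, has not yet been measured. It differs from compound 2 in one place: a group of 10 heavy atoms (7 carbon, 2 nitrogen, 1 sulfur; one six-membered aromatic ring of carbon only) in place of a group of 7 heavy atoms (5 carbon, 1 nitrogen, 1 oxygen; one six-membered non-aromatic ring with 1 hetero atom), on an aromatic carbon.

Among the compounds with values here, the only measured step on this core shows that changing the group at this place can move the number a long way. A change of this size is expected to give a step beyond the scatter in this assay, toward a higher number. Compound 4 is therefore expected to give about 3000 nM, between 500 nM and 20000 nM. The expected step is an 11-fold higher number from compound 2 to compound 4 (1.05 log units; beyond the scatter).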

Compound 4, half-maximal inhibitory concentration: 150 nM
Estimate against measurement, compound 4: 20-fold (1.30 log units) above; the whole stated range lies above it.
By their numbers in this assay, from the lowest: compounds 4 and 2 (each within the scatter of the next); then compound 1.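

In this assay, putting a larger group that carries a six-membered aromatic ring in place of the 2-oxopiperidin-1-yl group gives a 1.8-fold lower number from compound 2 to compound 4 (0.26 log units; within the scatter). Within the data shown here, this is the first step that isolates this place on the aromatic carbon, and it shows that two very different groups, one a non-aromatic ring without hydrogen-bond donors and the other an aromatic ring joined through a sulfur-bearing chain with hydrogen-bond donors, give numbers that cannot be told apart. Nothing shown here explains why such different groups read alike.

As far as these compounds go, it remains open whether a much smaller or charged group at this place, such as a primary amine or a carboxylic acid, would keep the number in the same range. From the compounds shown here alone, the part played by the sulfur also remains open, and a urea with oxygen in its place would test it.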